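The compounds below may be only part of what the source reports. "The series", "measured", "known", "first", "only" and "open" are said of these compounds alone.

Measured so far:
compound 1 `CC(C)(O)c1nc(-c2cccc(CNC(=O)c3cnc(-c4ccccn4)nc3)c2)no1` – 7.48 nM
compound 2 `O=C(NCc1ccccc1)c1cnc(-c2ccccc2)nc1` – 11.7 nM

Among the compounds with values here, in an assay on isolated protein for inhibition of Hematopoietic prostaglandin D synthase (Homo sapiens), read by fluorescence polarization (a lower number here means a stronger inhibitor, a higher number a weaker inhibitor), compound 2 gives 11.7 nM, the higher of the two numbers so far; compound 1, which gives 7.48 nM, sits close to it, and the gap between the two lies within the usual scatter, so no order between them can be read. Both compounds share the amide-linked pyrimidine core shown in their structures; compound 1 additionally carries the hydroxy-propyl oxadiazole on its benzyl ring and a pyridyl in place of the phenyl.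

Compound 3 `CC(C)(O)c1nc(-c2cccc(CNC(=O)c3cnc(-c4ccccc4)nc3)c2)no1` is compound 2 with one change: 5-(1-hydroxy-1-methylethyl)-1,2,4-oxadiazol-3-yl in place of hydrogen on an aromatic carbon, meta to a large group. Within the data shown here, no measured pair isolates this change. Among the measured compounds shown here, the only guide is that compound 1, which carries the same group, and compound 2, which lacks it, lie within the scatter of each other in this assay. The step from compound 2 to compound 3 is therefore expected to be small, a 1.4-fold lower number from compound 2 to compound 3 (0.14 log units; within the scatter), with no direction beyond the scatter. For compound 3 the expected value is 8.5 nM, with a range from 3 nM to 25 nM.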

Compound 3, half-maximal inhibitory concentration: 7.18 nM
Compound 3: middle estimate off by 1.2-fold (0.07 log units), on the high side, within the range that was stated.
By their numbers in this assay, from the lowest: compounds 3, 1 and 2 (each within the scatter of the next).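

The single-place step for adding 5-(1-hydroxy-1-methylethyl)-1,2,4-oxadiazol-3-yl in place of hydrogen, on a six-membered aromatic ring of carbon only and meta to a large group, reads in this assay as a 1.6-fold lower number from compound 2 to compound 3 (0.21 log units; within the scatter) and so shows that this position takes the group with no change that can be separated from the scatter. The other difference can now also be read alone: phenyl in place of pyridin-2-yl on an aromatic carbon gives a 1.0-fold lower number from compound 1 to compound 3 (0.02 log units; within the scatter) and likewise stays inside the scatter. Compound 1 and compound 2 differ in two places and could not separate these changes, whereas each change now has its own pair, and neither step in this assay can be given a direction.

Still open, from the compounds shown here alone, is whether an amine or a carboxylic acid at the same place, or a simple methyl on the oxadiazole in place of 1-hydroxy-1-methylethyl, would also stay within the scatter of compound 2. No independent evidence on hand bears on these two results.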